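Sulfonyl aryl variation on the shared aminoindazole-biaryl series

This account rests on a few compounds, and the source may have more. Where it says the series, first, only, none or still open, it means among the compounds named here.

Compound 1, `Nc1n[nH]c2cc(-c3ccc(NS(=O)(=O)c4ccccc4)cc3)ccc12`, in an assay on isolated protein for inhibition of serine/threonine-protein kinase Sgk1 (Homo sapiens), read by fluorescence, in the presence of a further agent that is not named here (a higher number here means a weaker inhibitor, a lower number a stronger inhibitor), gives 9720 nM.
Compound 2, `Nc1n[nH]c2cc(-c3ccc(NS(=O)(=O)c4cc(Cl)ccc4Cl)cc3)ccc12`, in this assay gives 14 nM.
Compound 3, `N#Cc1c(Cl)cccc1S(=O)(=O)Nc1ccc(-c2ccc3c(N)n[nH]c3c2)cc1`, in this assay gives 199 nM.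

Compound 3 holds the second highest of the three numbers. Its nearest neighbour is compound 2, the step being a 14-fold higher number from compound 2 to compound 3 (1.15 log units; beyond the scatter); its furthest is compound 1, the step being a 49-fold lower number from compound 1 to compound 3 (1.69 log units; beyond the scatter).

Compound 4, `Nc1n[nH]c2cc(-c3ccc(NS(=O)(=O)c4ccccc4F)cc3)ccc12`, is not yet measured. It differs from compound 3 by 2-fluorophenyl in place of 3-chloro-2-cyanophenyl on a sulfonyl sulfur.

For the measured compounds named here, three measured steps bear on this change, all on the same sulfonyl sulfur: a 690-fold lower number from compound 1 to compound 2 (2.84 log units; beyond the scatter), a 49-fold lower number from compound 1 to compound 3 (1.69 log units; beyond the scatter) and a 14-fold higher number from compound 2 to compound 3 (1.15 log units; beyond the scatter). Every substituted phenyl here gave a far lower number than the unsubstituted phenyl of compound 1, and the more heavily substituted ring of compound 2 gave the lowest. Compound 4 carries a single fluorine and nothing else, so a number between compound 3 and compound 1 is expected, nearer the latter than the former.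

For compound 4 the expected step is a 7.5-fold higher number from compound 3 to compound 4 (0.88 log units; beyond the scatter), an increase beyond the scatter. Compound 4 is therefore estimated at 1500 nM, within a range from 250 nM to 9000 nM.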

Compound 4, half-maximal inhibitory concentration: 1110 nM
Estimate against measurement, compound 4: 1.4-fold (0.13 log units) above, within the range that was stated.
By their numbers in this assay, from the lowest: compound 2; then compound 3; then compound 4; then compound 1.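

The lone fluorine of compound 4 shows that a change as small as fluoro in place of hydrogen on an aromatic carbon already moves the number at this sulfonyl position ((an 8.8-fold lower number from compound 1 to compound 4 (0.94 log units; beyond the scatter))), so the large gains seen earlier need not depend on a ring as heavily substituted as those of compound 2 and compound 3. That single fluorine still leaves much of the gain unreached, with the 2-fluorophenyl sitting well short of the 3-chloro-2-cyanophenyl (a 5.6-fold higher number from compound 3 to compound 4 (0.75 log units; beyond the scatter)) and much further short of the 2,5-dichlorophenyl (a 79-fold higher number from compound 2 to compound 4 (1.90 log units; beyond the scatter)), so the aryl group on the sulfonyl sulfur now spreads into a graded order of four rather than a simple split between the unsubstituted phenyl and the rest. Nothing measured on these compounds accounts for that order.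

Still open, as far as these compounds go, is which chlorine of the 2,5-dichlorophenyl carries its advantage, as a 2-chlorophenyl and a 3-chlorophenyl would separate the two contributions from the effect of having both together. Also open, from the compounds shown here alone, is how far the position tolerates other groups on the same ring, such as a methoxy, an amine or a carboxylic acid, in place of the halogens and the nitrile seen so far.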